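This account rests on a few compounds, and the source may have more. Where it says the series, first, only, none or still open, it means among the compounds named here.

Measured compounds:
Compound 1 `CCCCc1cc2ccccc2nc1-c1cc(-c2ccccc2)no1`. In a functional assay on PC-3 cells (Homo sapiens) for inhibition, read by MTT assay, with a stated time of 24 h (on this read-out lower numbers stand for stronger inhibition and higher numbers for weaker inhibition), compound 1 gives > 100000 nM, which is a limit of the assay and not a number.
Compound 2 `CCCCc1cc2ccccc2nc1-c1cc(-c2ccc(F)cc2)no1`. In this assay compound 2 gives 26300 nM.
Compound 3 `CCCc1cc2ccccc2nc1-c1cc(-c2ccc(C)cc2)no1`. In this assay compound 3 gives > 100000 nM, again a limit of the assay and not a number.

Compound 3 therefore stands at the ceiling of what the read-out reports, as described by the limit of > 100000 nM in this assay, at which 2 of the 3 values shown sit. Going by the values given here, the only step measured beyond the scatter is an at least 3.8-fold lower number from compound 1 to compound 2 (0.58 log units; beyond the scatter), a change on the aromatic substituent.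

Compound 4 `CCCCc1cc2ccccc2nc1-c1cc(-c2ccc(C)cc2)no1` differs from compound 3 by methyl in place of hydrogen on a saturated chain carbon, three bonds along the chain from an aromatic carbon, so propyl becomes butyl. Among the compounds with values here, no measured step alters this chain; the one measured step concerns the aromatic substituent and does not bear on it. Compound 1 already carries the butyl chain and sits at the limit, and compound 3 sits at the limit as well. The step of a number no higher from compound 3 to compound 4 (the limit leaves the size open) is expected to stay within the scatter. Compound 4 is estimated at 100000 nM, ranging from 30000 nM to 300000 nM, most likely reported as another limit.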

Compound 4, half-maximal inhibitory concentration: > 100000 nM
Compound 4: only a limit was reported (the forecaster's own chance of this, stated with the estimate: 65%); the middle value sits exactly at the limit.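

Going from propyl to butyl leaves compound 4 at the ceiling of this assay: compound 4 gives > 100000 nM, which is a limit of the assay and not a number. Going by these compounds alone, the steps to compound 4 from compound 3 and from compound 1 cannot be read, as both ends are limits, so the only readable comparison is with the fluoro compound on the same butyl chain, where methyl in place of fluoro on an aromatic carbon gives an at least 3.8-fold higher number from compound 2 to compound 4 (0.58 log units; beyond the scatter). Compound 2 is now the only compound shown that gives a number, and the others stay at the ceiling: the limit of > 100000 nM in this assay, at which 3 of the 4 values shown sit.

As far as these compounds go, what a hexyl chain in place of butyl, or an amine or a carboxylic acid in place of fluoro on that aromatic carbon, would give in this assay stays open. From the compounds shown here alone, whether fluoro also yields a number on the propyl chain stays open too.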